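Swapping an Oxane for a Difluorophenyl in a Lipophilic Series

A few compounds are considered here, and "the series" means these few. Any claim that something is new, unique, unknown or untested is made for them only; others in the source may bear on it.

Compound 1, `Cc1cc(C(=O)Nc2ccccc2)nn1Cc1cc(Cl)ccc1OCc1ccccc1`: > 3.7
Compound 2, `Cc1cc(NC(=O)C2CCOCC2)nn1Cc1cc(Cl)ccc1OCc1ccccc1`: > 3.7

Both measured compounds share one core and differ only in the group attached to the amide. The value of compound 1 in a physicochemical assay for lipophilicity, at pH 7.4 (a lower number here means a more polar compound, a higher number a more lipophilic compound), is a limit of the assay, not a number. The value of compound 2 in this assay is likewise only a limit. Compound 2 therefore stands at the limit of > 3.7 in this assay, at which 2 of the 2 values shown sit, and the step that the two limits leave unreadable from compound 1 to compound 2 cannot be sized.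

Compound 3, `Cc1cc(NC(=O)c2c(F)cccc2F)nn1Cc1cc(Cl)ccc1OCc1ccccc1`, is not yet measured. It differs from compound 2 by 2,6-difluorophenyl in place of oxan-4-yl on a carbonyl carbon. Among the measured compounds shown here, the only measured step is unreadable, so no sized step bears on this change. Compound 3 is expected to sit again at or past the limit, a step that the limit leaves unreadable from compound 2 to compound 3 being estimated. The estimate for compound 3 is 5, within 4.2 to 5.8.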

Compound 3, distribution coefficient: > 3.7
Compound 3 gave a limit, no number (the forecaster's own chance of this, stated with the estimate: 85%); the middle value lies beyond the limit too.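

In this assay, compound 3 gives only a limit, as compound 1 and compound 2 do, so no step among these three compounds can be read: the limit of > 3.7 in this assay, at which 3 of the 3 values shown sit.

The compounds shown leave open where each truly lies, and whether 2,6-difluorophenyl in place of oxan-4-yl changes the read-out at all.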